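Replacing trifluoromethyl with hydroxyethyl at a chain end

This account rests on a few compounds, and the source may have more. Where it says the series, first, only, none or still open, it means among the compounds named here.

Measured so far in an ADME assay on HEp-2 cells (Homo sapiens) for cytotoxicity; on this read-out higher numbers stand for lower toxicity in this test and lower numbers for higher toxicity in this test:
Compound 1 `N#CCCCn1c(Cn2c(=O)n(Cc3ccc(C#N)cc3)c3ccncc32)nc2ccccc21` gives 36800 nM.
Compound 2 `O=c1n(Cc2nc3ccccc3n2CCCC(F)(F)F)c2cnccc2n1C1CC1` gives 55700 nM.
Compound 3 `N#CCCCn1c(Cn2c(=O)n(C3CCC3)c3ccncc32)nc2ccccc21` gives only a limit of the test, > 258000 nM.

Compound 2 holds the highest of the two plain numbers, with compound 1 a little lower, and the gap between them lies within the scatter, so the two read as alike. Compound 4 `O=c1n(Cc2nc3ccccc3n2CCCCCO)c2cnccc2n1C1CC1` differs from compound 2 in one place: 2-hydroxyethyl in place of trifluoromethyl on a saturated chain carbon, three bonds along the chain from an aromatic nitrogen. Among the compounds with values here, the only measured step, an at least 7.0-fold higher number from compound 1 to compound 3 (0.84 log units; beyond the scatter), alters a group on an aromatic nitrogen of the shared core rather than the chain, so it offers no direct guide to this change. One of the three values sits at the limit of > 258000 nM in this assay, at which 1 of the 3 values shown sits, showing that numbers in this test can run up to its upper limit. With nothing to draw on for the chain, compound 4 is expected to land near compound 2, at an estimated 80000 nM (range 30000 nM to 258000 nM). The step of a 1.4-fold higher number from compound 2 to compound 4 (0.16 log units; within the scatter) is expected to be small, within or barely beyond the scatter.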

Compound 4, half-maximal cytotoxic concentration: > 229000 nM
Compound 4 was reported as a limit; the forecaster's own chance of this, stated with the estimate: 30%; at least 2.8-fold (0.45 log units) between middle value and limit.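

In this assay, the end of the chain also matters: 5-hydroxypentyl in place of 4,4,4-trifluorobutyl gives an at least 4.1-fold higher number from compound 2 to compound 4 (0.61 log units; beyond the scatter). Within the data shown here, until now, the only step beyond the scatter came from a change on an aromatic nitrogen of the shared core, whereas this one shows that a change at the chain end can also move the read-out towards lower toxicity in this test. Compound 4 gives > 229000 nM, which is a limit and not a number, so the step has no known upper size: the limit of > 229000 nM in this assay, at which 1 of the 4 values shown sits.

This single pair cannot separate losing trifluoromethyl from gaining the hydroxyl group, and a plain pentyl chain, an amine or a carboxylic acid at the chain end would help to tell these apart. From the compounds shown here alone, it also remains open whether the 5-hydroxypentyl chain has the same effect with 4-cyanobenzyl on the aromatic nitrogen of the shared core.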